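The source may hold more compounds than are shown below. What is called first, only, known or untested is meant among the compounds shown, and "the series" means these compounds.

For the measured compounds named here, in a functional assay on HeLa S3 cells (Homo sapiens) for cytotoxicity, read by XTT assay, with a stated time of 3 days (a higher number here means a weaker inhibitor, a lower number a stronger inhibitor), compound 2 `OC[C@H]1O[C@@H](n2cc(F)c3c(-c4ccoc4)ncnc32)[C@H](O)[C@@H]1O` gives 170 nM, the lower of the two numbers measured so far, while compound 1 `OC[C@H]1O[C@@H](n2cc(F)c3c(-c4c[nH]cn4)ncnc32)[C@H](O)[C@@H]1O` gives 12200 nM. The next compound, compound 3 `OC[C@H]1O[C@@H](n2cc(F)c3c(-c4cc[nH]c4)ncnc32)[C@H](O)[C@@H]1O`, keeps the shared core and changes only the group on an aromatic carbon, with 1H-pyrrol-3-yl in place of furan-3-yl (1H-pyrrol-3-yl in place of furan-3-yl on an aromatic carbon). Both groups are five-membered aromatic rings with 1 hetero atom. Going by the values given here, only one measured step bears on this change, and only indirectly: a 72-fold lower number from compound 1 to compound 2 (1.86 log units; beyond the scatter), where furan-3-yl took the place of 1H-imidazol-4-yl. That large step shows that exchanging one five-membered aromatic ring for another at this carbon can move the number far in this assay. It does not involve the pyrrolyl group, however, and so gives no direction for this exchange. No step beyond the scatter is therefore expected, though with wide uncertainty, and the estimate is a 1.2-fold higher number from compound 2 to compound 3 (0.07 log units; within the scatter). For compound 3 the expected value is 200 nM, with an estimated range from 50 nM to 1000 nM.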

Compound 3, half-maximal inhibitory concentration: 8900 nM
Beside the measured number, compound 3's estimate is 45-fold (1.65 log units) below it; the whole stated range lies below it.
By their numbers in this assay, from the lowest: compound 2; then compounds 3 and 1 (each within the scatter of the next).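

In this assay, 1H-pyrrol-3-yl in place of furan-3-yl gives a 52-fold higher number from compound 2 to compound 3 (1.72 log units; beyond the scatter), so at this aromatic carbon, two groups with the same ring size and the same count of heavy atoms are far apart, and exchanging the ring oxygen for a ring nitrogen alone is enough to produce a large step. For the compounds shown here, the other new step, a 1.4-fold lower number from compound 1 to compound 3 (0.14 log units; within the scatter), does not separate 1H-pyrrol-3-yl from 1H-imidazol-4-yl, which leaves furan-3-yl as the only one of the three groups whose number lies beyond the scatter from both others. No measurement at hand accounts for the size of this step.

The three compounds leave open whether the low number belongs to furan-3-yl alone or extends to other rings at this carbon, such as thiophen-3-yl, with sulfur as its hetero atom, or furan-2-yl, with the same ring attached through a different carbon. They also leave open whether 1-methyl-1H-pyrrol-3-yl, which replaces the hydrogen on the ring nitrogen with a methyl group, would stay with compound 3 or move towards compound 2.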